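The source may report more compounds than this note shows. Statements on the series, on what has been measured and on what is new or still open speak of the compounds shown alone.

In a functional assay on MCF7 cells (Homo sapiens) for cytotoxicity, read by MTT assay, with a stated time of 6 days (a lower number here means that less compound is needed, a higher number that more compound is needed for the effect), compound 1 (`COC(=O)c1c(-c2ccc([N+](=O)[O-])cc2)oc2ccccc2c1=O`) gives > 25 ug/mL as a limit of the assay. Compound 2 (`COC(=O)c1c(-c2ccc(N)cc2)oc2ccccc2c1=O`) gives > 25 ug/mL as a limit too. Compound 3 (`COC(=O)c1c(-c2ccc(OCc3ccccc3)cc2)oc2ccc(OC)cc2c1=O`) gives > 25 ug/mL as a limit as well. Compound 2 therefore has no number, and it stands at the limit of > 25 ug/mL in this assay, at which 3 of the 3 values shown sit, with nothing to set it apart. The change to compound 4 (`COC(=O)c1c(-c2ccc(O)cc2)oc2ccccc2c1=O`) is hydroxy in place of amino on an aromatic carbon. Going by the values given here, the one measured step at this place (a step that the two limits leave unreadable from compound 1 to compound 2) has no readable size, so no step beyond the scatter is expected in either direction in this assay for this change. The estimated step is small (a step that the limit leaves unreadable from compound 2 to compound 4). Compound 4 is estimated at 30 ug/mL within a range from 12 ug/mL to 60 ug/mL and is expected quite possibly to appear as a limit again.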

Compound 4, concentration for half-maximal effect: > 25 ug/mL
Compound 4: only a limit was reported; the forecaster's own chance of this, stated with the estimate: 70%; the middle value lies beyond the limit too.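

In this assay compound 4 gives > 25 ug/mL, which is a limit of the assay and not a number. Going by these compounds alone, no step from compound 1 or compound 2 to compound 4 can be read. The compounds shown leave open whether nitro, amino and hydroxy differ at all in this assay.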